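This account rests on a few compounds, and the source may have more. Where it says the series, first, only, none or still open, it means among the compounds named here.

Measured so far in an ADME assay on MT4 cells (Homo sapiens) for cytotoxicity, read by MTT assay (on this read-out higher numbers stand for lower toxicity in this test and lower numbers for higher toxicity in this test), for this series:
- compound 1 `COC(=O)c1ccc(NC(=O)CSc2nncnc2-c2cccc3ccccc23)c(Br)c1` gives 173000 nM
- compound 2 `CC(=O)c1ccc(NC(=O)CSc2nncnc2-c2cccc3ccccc23)c(Br)c1` gives 133000 nM

Within the data shown here, compound 2 and compound 1 lie within the scatter of each other, so the two cannot be ranked and compound 2 stands level with the only other number available. Among the measured compounds shown here, the next compound to read is compound 3 `CCOC(=O)c1ccc(NC(=O)CSc2nncnc2-c2cccc3ccccc23)c(Br)c1` with ethoxy in place of methyl on a carbonyl carbon as its sole change from compound 2. For the measured compounds named here, only one measured step bears on this change, namely a 1.3-fold lower number from compound 1 to compound 2 (0.11 log units; within the scatter) for methyl in place of methoxy on a carbonyl carbon. Going by the values given here, that step stayed within the scatter, though it is a single pair and no measured step covers ethoxy itself. For compound 3 the expectation is a 1.2-fold higher number from compound 2 to compound 3 (0.07 log units; within the scatter) as the estimated size, which means no step beyond the scatter in this assay and no firm direction. The estimate for compound 3 is 155000 nM with an expected range from 85000 nM to 280000 nM for this read-out.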

Compound 3, half-maximal cytotoxic concentration: 105000 nM
Beside the measured number, compound 3's estimate is 1.5-fold (0.17 log units) above it; low and high end bracket the measured number.
By their numbers in this assay, from the lowest: compounds 3, 2 and 1 (each within the scatter of the next).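

In this assay the place on a carbonyl carbon whose other neighbour is an aromatic carbon has now carried methyl, methoxy and ethoxy, and the new compound adds two readings. Ethoxy in place of methyl gives a 1.3-fold lower number from compound 2 to compound 3 (0.10 log units; within the scatter), a change from 1 heavy atom to 3 heavy atoms that stays within the scatter, and methyl in place of hydrogen on a saturated chain carbon bound to an oxygen next to a carbonyl group gives a 1.6-fold lower number from compound 1 to compound 3 (0.22 log units; within the scatter), which also stays within the scatter. The three compounds therefore cannot be ranked at this place, and no evidence on hand bears on this result.

Still open, going by these compounds, is whether a carboxylic acid, a primary amide or a longer chain such as butoxy on this carbonyl carbon would move the number beyond the scatter, or whether this place stays flat across a wider range of groups. Also open, on these data alone, is whether the same holds when the bromo group is exchanged for another halogen such as chloro, since all three compounds carry bromo.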